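Moving the formyl group: an isomer of a weak analogue

This account rests on a few compounds, and the source may have more. Where it says the series, first, only, none or still open, it means among the compounds named here.

Compound 1 `COC(=O)c1ccccc1OCc1cn(-c2ccc(S(=O)(=O)N3CCc4ccccc4C3)cc2)nn1` gives 630 nM in a functional assay on HuCC-A1 cells (Homo sapiens) for cytotoxicity, read by MTT assay, with a stated time of 48 h; a lower number here means a stronger inhibitor, a higher number a weaker inhibitor.
Compound 2 `COc1cc2c(cc1OC)CN(S(=O)(=O)c1ccc(-n3cc(COc4cc(C=O)ccc4OC)nn3)cc1)CC2` gives 76200 nM in this assay.

Compound 2 has the highest number of the two; its gap to compound 1 lies beyond the usual scatter. Compound 3 `COc1cc2c(cc1OC)CN(S(=O)(=O)c1ccc(-n3cc(COc4ccc(C=O)cc4OC)nn3)cc1)CC2` keeps the same atoms joined differently: 4-formyl-2-methoxyphenyl in place of 5-formyl-2-methoxyphenyl on an oxygen on a saturated carbon. Nothing measured here tells how such a swap shifts the number, so no step beyond the scatter is expected. The estimate means a step of a 1.5-fold lower number from compound 2 to compound 3 (0.18 log units; within the scatter) in this assay, expected within scatter. Compound 3 is expected to give 50000 nM, in the range 12000 nM to 200000 nM.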

Compound 3, half-maximal inhibitory concentration: 40000 nM
For compound 3 the middle estimate is 1.3-fold (0.10 log units) above the measured one; the range from low to high includes it.
By their numbers in this assay, from the lowest: compound 1; then compounds 3 and 2 (each within the scatter of the next).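

Putting 4-formyl-2-methoxyphenyl in place of 5-formyl-2-methoxyphenyl gives a 1.9-fold lower number from compound 2 to compound 3 (0.28 log units; within the scatter) in this assay. At this place on the oxygen, then, the two formyl isomers cannot be told apart, and both of these compounds keep numbers in the same weak range. Nothing available offers an explanation for this result.

Going by these compounds, whether a carboxylic acid or an amine in place of the formyl group would shift the number remains open. Compound 1 differs from both isomers in more than one place, so its far lower number cannot be tied to any single group.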